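Trading methoxy for trifluoromethyl on compound 2

The compounds below may be only part of what the source reports. "The series", "measured", "known", "first", "only" and "open" are said of these compounds alone.

compound 1 `CCCCc1ccc2[nH]c(-c3ccc(C(F)(F)F)cc3)c(/C=N/NC(=O)c3ccc(OC)cc3)c2c1`: 284 nM
compound 2 `CCCCc1ccc2[nH]c(-c3ccc(OC)cc3)c(/C=N/NC(=O)c3cccnc3)c2c1`: 35 nM

In a functional assay on MDA-MB-231 cells (Homo sapiens) for antiproliferative activity, with a stated time of 4 days (on this read-out higher numbers stand for weaker inhibition and lower numbers for stronger inhibition), compound 2 gives 35 nM, the lower of the two numbers and so the stronger inhibition. Its gap to compound 1 lies beyond the scatter. These two compounds differ in more than one place, and the data do not show which difference accounts for the gap.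

Compound 3 `CCCCc1ccc2[nH]c(-c3ccc(C(F)(F)F)cc3)c(/C=N/NC(=O)c3cccnc3)c2c1` is compound 2 with one change: trifluoromethyl in place of methoxy on an aromatic carbon, para to a large group (trifluoromethyl in place of methoxy on an aromatic carbon). Among the measured compounds shown here, no measured pair shows this swap alone, so its size can only be estimated. Compound 3 shares the 4-(trifluoromethyl)phenyl group with compound 1, which gives 284 nM, and its other varied group with compound 2, which gives 35 nM. A number between these two therefore seems the most reasonable expectation. The expected change is a 2.9-fold higher number from compound 2 to compound 3 (0.46 log units; beyond the scatter), a moderate move towards weaker inhibition. For compound 3 the estimated value is 100 nM, with an expected range from 35 nM to 300 nM.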

Compound 3, half-maximal inhibitory concentration: 97 nM
For compound 3 the middle estimate is 1.0-fold (0.01 log units) above the measured one; the measured number falls inside the stated range.
By their numbers in this assay, from the lowest: compound 2; then compound 3; then compound 1.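

In this assay, the change from 4-methoxyphenyl to 4-(trifluoromethyl)phenyl, with methoxy leaving and trifluoromethyl entering on an aromatic carbon para to a large group, gives a 2.8-fold higher number from compound 2 to compound 3 (0.44 log units; beyond the scatter), so this position alone shifts the number and methoxy is the better of the two groups here. At the other varied place, pyridin-3-yl in place of 4-methoxyphenyl on a carbonyl carbon gives a 2.9-fold lower number from compound 1 to compound 3 (0.47 log units; beyond the scatter), so the gap that could not be assigned between the first two compounds now resolves into two single changes, each beyond the scatter and each favouring the group found in compound 2. No measurement here accounts for why either change moves the number as it does.

On these data alone, each swap appears only once, against a single partner group, so it remains open whether either step keeps its size when the group at the other place differs. Also open, as far as these compounds go, is how this position responds to other groups on the same aromatic carbon, such as a chlorine atom, a hydroxyl group or an amine.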